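Extending the side chain of compound 2

The source may report more compounds than this note shows. Statements on the series, on what has been measured and on what is new or still open speak of the compounds shown alone.

Measured in an ADME assay on MDCK cells (Canis lupus familiaris) for cytotoxicity, read by MTT assay, with a stated time of 48 h; on this read-out higher numbers stand for lower toxicity in this test and lower numbers for higher toxicity in this test:
compound 1 `COC(=O)CC[C@H](NC(=O)CSc1nc(-c2ccccc2)cc(-c2ccc(C)cc2)c1C#N)C(=O)OC`: > 250000 nM (a limit)
compound 2 `Cc1ccc(-c2cc(-c3ccccc3)nc(SCC(=O)N[C@H](C(=O)O)C(C)C)c2C#N)cc1`: > 250000 nM (a limit)

Compound 2 gives only a limit, > 250000 nM, and no actual number. Going by the values given here, the whole series so far rests on this: the limit of > 250000 nM in this assay, at which 2 of the 2 values shown sit. Among the compounds with values here, the one measured step is a step that the two limits leave unreadable from compound 1 to compound 2, so it offers no size to carry forward, although that step also rebuilt the group on the amide nitrogen.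

Compound 3 `Cc1ccc(-c2cc(-c3ccccc3)nc(SCC(=O)N[C@H](C(=O)N[C@@H](CC(=O)O)C(=O)O)C(C)C)c2C#N)cc1` has (1,2-dicarboxyethyl)amino in place of hydroxy on a carbonyl carbon. Within the data shown here, with only that unreadable step as a guide, no change beyond the usual scatter is expected in this assay, and no direction can be named. The expected move is a number no higher from compound 2 to compound 3 (the limit leaves the size open). Compound 3 is estimated at 250000 nM, with a range of 120000 nM to 500000 nM, and will probably be reported as a limit again.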

Compound 3, half-maximal cytotoxic concentration: > 250000 nM
Compound 3: no number, only a limit (the forecaster's own chance of this, stated with the estimate: 85%); the middle value lies on the limit itself.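

In this assay compound 3 gives only a limit, > 250000 nM, so no size can be read for its step from compound 2: the limit of > 250000 nM in this assay, at which 3 of the 3 values shown sit.

The compounds shown leave open what concentration of compound 1, compound 2 or compound 3 would actually harm these cells, and whether the side-chain changes alter it.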